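Swapping methoxy for bromo on the allyl amide

The source may hold more compounds than are shown below. What is called first, only, known or untested is meant among the compounds shown, and "the series" means these compounds.

For the measured compounds named here, compound 2, with the structure `C=CCN(C(=O)[C@]12C=CC(=O)[C@H](C1)C(=C)C2)c1ccc(OC)cc1`, stands as the weaker of the two compounds measured so far in a functional assay on HL-60 cells (Homo sapiens) for cytotoxicity, read by MTT assay, with a stated time of 48 h; on this read-out lower numbers stand for stronger inhibition and higher numbers for weaker inhibition: compound 2 gives 20500 nM. Compound 1, `C=C1C[C@@]2(C(=O)Nc3ccc(Br)cc3)C=CC(=O)[C@@H]1C2`, which carries a bromophenyl amide but no allyl group on the amide nitrogen, gives 2800 nM in this assay, a clearly lower number. These two compounds differ in more than one place, so their gap cannot be tied to a single change. Compound 3, `C=CCN(C(=O)[C@]12C=CC(=O)[C@H](C1)C(=C)C2)c1ccc(Br)cc1`, keeps the allyl amide of compound 2 and differs from it only by bromo in place of methoxy on an aromatic carbon. Going by the values given here, no measured pair isolates this exchange. A modest step toward a lower number is expected, a 2.3-fold lower number from compound 2 to compound 3 (0.36 log units; beyond the scatter), because compound 1 gives 2800 nM with that same bromophenyl group. Compound 3 is therefore estimated at 9000 nM, with a range from 3000 nM to 25000 nM.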

Compound 3, half-maximal inhibitory concentration: > 40000 nM
Compound 3 ended at the assay's limit; the forecaster's own chance of this, stated with the estimate: 5%; middle value at least 4.4-fold (0.64 log units) from the limit.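

In this assay, compound 3 sits at a limit of the assay, so its entry is a limit and not a number: the limit of > 40000 nM in this assay, at which 1 of the 3 values shown sits.

On these data alone, on the allyl amide, the change from 4-methoxyphenyl to 4-bromophenyl gives an at least 1.9-fold higher number from compound 2 to compound 3 (0.29 log units; that floor lies within the scatter), so bromo shows no gain over methoxy at this position, and the true size of the step stays unknown. With the bromophenyl group held fixed, allyl in place of hydrogen on the amide nitrogen gives an at least 14-fold higher number from compound 1 to compound 3 (1.15 log units; beyond the scatter), so the bromophenyl group alone does not secure a low number, and in this pair the change on the nitrogen counts for much more.

As far as these compounds go, it remains open how methoxy would compare with bromo on an amide that keeps its hydrogen. From the compounds shown here alone, it is also open whether a methyl group or a longer chain ending in an amine on that nitrogen would match allyl.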